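Removing the methoxy from the benzamide of an orexin agonist

A few compounds are considered here, and "the series" means these few. Any claim that something is new, unique, unknown or untested is made for them only; others in the source may bear on it.

Compound 3 `COc1ccccc1C(=O)NCCNc1cccc(NS(=O)(=O)c2cc(-c3cccc(C(=O)N(C)C)c3)ccc2OC)c1` gives 50 nM in an assay on CHO-K1 cells for agonist activity at Orexin receptor type 2 (Homo sapiens), read by a luciferase reporter (on this read-out higher numbers stand for an effect only at larger amounts of compound and lower numbers for an effect already at smaller amounts), the lowest of the two numbers recorded. Compound 2 `CNC(=O)c1cccc(-c2ccc(OC)c(S(=O)(=O)Nc3cccc(NCCNC(=O)c4ccccc4OC)c3)c2)c1` gives 182 nM in this assay, and the step of a 3.6-fold lower number from compound 2 to compound 3 (0.56 log units; beyond the scatter) lies beyond the scatter. Compound 1 `COc1ccccc1C(=O)NCCNc1cccc(NS(=O)(=O)c2cc(-c3ccccc3)ccc2OC)c1` reaches only the limit > 10000 nM in this assay, (the limit of > 10000 nM in this assay, at which 1 of the 3 values shown sits). The steps of an at least 54-fold lower number from compound 1 to compound 2 (1.73 log units; beyond the scatter) and an at least 200-fold lower number from compound 1 to compound 3 (2.30 log units; beyond the scatter) were large. Compound 4 `COc1ccc(-c2cccc(C(=O)N(C)C)c2)cc1S(=O)(=O)Nc1cccc(NCCNC(=O)c2ccccc2)c1` differs from compound 3 by hydrogen in place of methoxy on an aromatic carbon. Going by the values given here, all three measured steps concern the carboxamide introduced in compounds 2 and 3; none of them touches the benzamide, so no measured step bears on this change. The expectation for compound 4 therefore rests only on the value of compound 3, 50 nM. The step of a 2.0-fold higher number from compound 3 to compound 4 (0.30 log units; within the scatter) is expected to be modest, with its direction uncertain. Compound 4 is estimated at 100 nM in this assay, within a range from 30 nM to 400 nM.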

Compound 4, half-maximal effective concentration: > 10000 nM
Compound 4 gave a limit, no number (the forecaster's own chance of this, stated with the estimate: 5%); at least 100-fold (2.00 log units) between middle value and limit.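

Hydrogen in place of methoxy on this aromatic carbon, ortho to a large group, gives an at least 200-fold higher number from compound 3 to compound 4 (2.30 log units; beyond the scatter), so the benzamide end of the molecule also governs the read-out, which the earlier steps, all at the carboxamide, could not show. In this assay compound 4 gives > 10000 nM, which is a limit of the assay and not a number. The dimethylcarbamoyl group of compound 3 is still present in compound 4 and does not keep a measurable value without the methoxy, and that limit now marks two of the compounds: the limit of > 10000 nM in this assay, at which 2 of the 4 values shown sit.

As far as these compounds go, whether the methoxy itself is needed stays open, as a hydroxy, an ethoxy or a fluorine on the same carbon might serve in its place. From the compounds shown here alone, how a methoxy elsewhere on that ring would read also remains unknown.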